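Benzylamine aryl swap in the sulfonamide series

The source may report more compounds than this note shows. Statements on the series, on what has been measured and on what is new or still open speak of the compounds shown alone.

Compound 2 `O=S(=O)(NCCCNCc1ccc(Cl)cc1)c1cc(C(F)(F)F)cc(C(F)(F)F)c1` and compound 1 `O=S(=O)(NCCCNCc1ccc(Cl)c(Cl)c1)c1cc(C(F)(F)F)cc(C(F)(F)F)c1` share the same core and differ only by a chloro group on the aromatic ring of the benzylamine. In a functional assay on ASPC1 cells (Homo sapiens) for inhibition, read by MTT assay, with a stated time of 72 h (on this read-out lower numbers stand for stronger inhibition of growth and higher numbers for weaker inhibition of growth), compound 1 gives 2800 nM and compound 2 gives 3000 nM. The step of a 1.1-fold higher number from compound 1 to compound 2 (0.03 log units; within the scatter) shows that removing that chloro leaves the read-out unchanged, so compound 2 stands on the same footing as compound 1 in this assay, with nothing to separate the two.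

Compound 3 `COc1ccccc1CNCCCNS(=O)(=O)c1cc(C(F)(F)F)cc(C(F)(F)F)c1` is not yet measured. It differs from compound 2 by 2-methoxyphenyl in place of 4-chlorophenyl on a saturated chain carbon bound to an amine nitrogen. Going by the values given here, the only measured step, the one from compound 1 to compound 2, touches the same aromatic ring and bears on it in that a change of substitution there gave no movement beyond the scatter. Among the compounds with values here, no measured step tests a methoxy group on this ring or a change of its position, so the expectation rests on that single flat step alone.

On that basis compound 3 is expected to show a 1.3-fold higher number from compound 2 to compound 3 (0.12 log units; within the scatter), that is no step beyond the scatter, with an estimate of 4000 nM and a range from 1500 nM to 12000 nM in this assay.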

Compound 3, concentration for 50% growth inhibition: 4600 nM
The estimate for compound 3 lay 1.2-fold (0.06 log units) below the measured number; the range from low to high includes it.
By their numbers in this assay, from the lowest: compounds 1, 2 and 3 (each within the scatter of the next).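

In this assay, the exchange of the aryl group gives a 1.5-fold higher number from compound 2 to compound 3 (0.19 log units; within the scatter) and a 1.6-fold higher number from compound 1 to compound 3 (0.22 log units; within the scatter), both within the scatter. The earlier step only took a chloro off the ring, whereas these two replace the whole substitution on the aryl group at this saturated chain carbon bound to an amine nitrogen, with a methoxy group and its hydrogen-bond acceptor entering and every chloro leaving, and still nothing separates compounds 1, 2 and 3. No measurement on hand accounts for this flat picture.

Compound 3 changes both the substituent and its place on the ring in a single step, so the compounds shown cannot tell whether either change alone would move the number or whether the two offset each other. A carboxylic acid or an amine on this aromatic ring, or a longer chain in the shared core, would show whether the flat picture extends to groups unlike the chloro and methoxy substituents seen so far.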